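The source may report more compounds than this note shows. Statements on the series, on what has been measured and on what is new or still open speak of the compounds shown alone.

Measured compounds in a functional assay on A549 cells (Homo sapiens) for cytotoxicity, read by MTT assay, with a stated time of 72 h; on this read-out lower numbers stand for stronger inhibition and higher numbers for weaker inhibition:
- compound 1, `CN(C)CCn1cnnc1-c1cc(Oc2ccc(NC(=O)N/N=C/c3c[nH]c4ccccc34)cc2F)ccn1`, gives 820 nM.
- compound 3, `CN(C)CCn1cnnc1-c1cc(Oc2ccc(NC(=O)N/N=C/c3cccc(Br)c3)cc2F)ccn1`, gives 970 nM.
- compound 2, `COc1cc(/C=N/NC(=O)Nc2ccc(Oc3ccnc(-c4nncn4CCN(C)C)c3)c(F)c2)cc(OC)c1OC`, reaches only the limit of > 100000 nM, so no number is known for it.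

Compound 3 sits close to compound 1: the gap is a 1.2-fold higher number from compound 1 to compound 3 (0.07 log units; within the scatter). The third compound gives only a limit, so compound 3 and compound 1 are the two with real numbers, and they cannot be told apart.

Compound 4, `COc1cc(/C=N/NC(=O)Nc2ccc(Oc3ccnc(-c4nncn4CCN(C)C)c3)c(F)c2)ccc1O`, differs from compound 3 in one place: 4-hydroxy-3-methoxyphenyl in place of 3-bromophenyl on a carbon with a double bond to nitrogen. Two measured steps speak to this. The exchange of 1H-indol-3-yl for 3-bromophenyl hardly mattered: a 1.2-fold higher number from compound 1 to compound 3 (0.07 log units; within the scatter). The exchange of 3,4,5-trimethoxyphenyl for 3-bromophenyl mattered greatly: an at least 100-fold lower number from compound 2 to compound 3 (2.01 log units; beyond the scatter). Among the measured compounds shown here, the incoming 4-hydroxy-3-methoxyphenyl shares oxygen substituents with the trimethoxyphenyl of compound 2, though fewer of them, so a higher number than compound 3 is expected, but a smaller rise than the one seen with compound 2. Compound 4 is therefore expected to give 10000 nM, between 1500 nM and 100000 nM, a step of a 10-fold higher number from compound 3 to compound 4 (1.01 log units; beyond the scatter).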

Compound 4, half-maximal inhibitory concentration: > 100000 nM
Compound 4 was reported as a limit; the forecaster's own chance of this, stated with the estimate: 25%; at least 10-fold (1.00 log units) between middle value and limit.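

In this assay compound 4 gives only a limit, not a number: > 100000 nM ( a limit of the assay ). The rise is large against both compounds with real numbers (an at least 100-fold higher number from compound 3 to compound 4 (2.01 log units; beyond the scatter); an at least 120-fold higher number from compound 1 to compound 4 (2.08 log units; beyond the scatter)), so carrying fewer oxygen substituents than the 3,4,5-trimethoxyphenyl of compound 2 brought no readable number back at this carbon. Both groups with oxygen substituents, in compound 2 and compound 4, now end at the same limit, and the step between these two compounds cannot be read: (the limit of > 100000 nM in this assay, at which 2 of the 4 values shown sit).

Going by these compounds, how far past the limit compound 2 and compound 4 lie stays unknown, so these two groups cannot be ranked. Also open, on these data alone, is whether a phenyl ring with a lone methoxy or a lone hydroxy, or one bearing an amine or a carboxylic acid, would stay close to the 3-bromophenyl of compound 3 (970 nM).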